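Trading the sulfonyl link for a carbonyl in compound 4

This account rests on a few compounds, and the source may have more. Where it says the series, first, only, none or still open, it means among the compounds named here.

Measured compounds:
Compound 1, `COc1ccc(CN(c2cc(OC)c(OC)c(OC)c2)S(=O)(=O)c2ccccc2)cc1`, in a functional assay on PC-3 cells (Homo sapiens) for inhibition, read by MTT assay, with a stated time of 48 h (a lower number here means a stronger inhibitor, a higher number a weaker inhibitor), gives > 50000 nM, which is a limit of the assay rather than a number.
Compound 2, `COc1cc(N(Cc2nc3ccccc3[nH]2)S(=O)(=O)c2ccccc2)cc(OC)c1OC`, in this assay gives 25500 nM.
Compound 3, `COc1cc(N(Cc2nc3ccccc3[nH]2)S(=O)(=O)c2ccc(C(C)(C)C)cc2)cc(OC)c1OC`, in this assay gives 29800 nM.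

Among the two plain numbers, compound 2 has the lower one, but its nearest neighbour, compound 3, sits within the usual scatter of it, so the two cannot be told apart. Compound 1 contributes only a limit, as noted above (the limit of > 50000 nM in this assay, at which 1 of the 3 values shown sits).

Compound 4, `COc1cc(N(Cc2nc3ccccc3[nH]2)C(=O)c2ccccc2)cc(OC)c1OC`, differs from compound 2 in one place: benzoyl in place of phenylsulfonyl on a nitrogen on an aromatic ring. Two measured steps surround this part of the molecule without touching it. The step of an at least 1.9-fold lower number from compound 1 to compound 2 (0.29 log units; that floor lies within the scatter) changed the group on the chain carbon attached to the same nitrogen, and the step of a 1.2-fold higher number from compound 2 to compound 3 (0.07 log units; within the scatter) added a tert-butyl to the phenylsulfonyl ring. Neither altered the sulfonyl group itself, and neither moved the number beyond the scatter. On that basis the change to a benzoyl group is expected to give no step beyond the scatter, a 1.0-fold lower number from compound 2 to compound 4 (0.01 log units; within the scatter). Compound 4 is therefore estimated at 25000 nM in this assay, with a range from 8000 nM to 80000 nM.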

Compound 4, half-maximal inhibitory concentration: > 50000 nM
Compound 4: no number, only a limit; the forecaster's own chance of this, stated with the estimate: 25%; middle value at least 2.0-fold (0.30 log units) from the limit.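

This is the first change shown at the link on the nitrogen itself, rather than at groups around it. In this assay compound 4 gives > 50000 nM, which is a limit of the assay and not a number. As a step this reads an at least 1.9-fold higher number from compound 2 to compound 4 (0.29 log units; that floor lies within the scatter), so the true gap could be small or much larger, and the data cannot place it beyond the scatter. What can be said is narrower: compound 2 and its tert-butyl relative compound 3 both give plain numbers, whereas each of the two single changes made to compound 2, in compound 1 on the chain carbon and in compound 4 at the phenylsulfonyl group, ends in a limit: the limit of > 50000 nM in this assay, at which 2 of the 4 values shown sit.

As far as these compounds go, how far compound 4 really lies from compound 2 stays unknown, so the data do not show whether the sulfonyl link matters or whether the benzoyl group is merely no better. From the compounds shown here alone, it is also open what this nitrogen would give with a smaller group in the same place, such as methanesulfonyl or acetyl, or with a plain benzyl group that has neither a sulfonyl nor a carbonyl link.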